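Lengthening the ketone chain in compound 3

The source may hold more compounds than are shown below. What is called first, only, known or untested is meant among the compounds shown, and "the series" means these compounds.

Compound 1 `Cc1c(OCCCCOc2ccccc2C(=O)O)ccc(C(=O)CC2CCCC2)c1O`: 98.8%
Compound 2 `COc1cc(C(=O)O)ccc1OCCCCOc1ccc(C(=O)CC(C)C)c(O)c1C`: 85.7%
Compound 3 `CCC(=O)c1ccc(OCCCCOc2cc(C(=O)O)ccc2OC)c(C)c1O`: 72.6%

In an assay on HEK293 cells for positive allosteric modulation of metabotropic glutamate receptor 2 (Rattus norvegicus), read by thallium flux, with a stated time of 2.5 min (on this read-out lower numbers stand for smaller maximal responses and higher numbers for larger maximal responses), compound 3 gives the lowest of the three numbers; compound 2 stands above it beyond the usual scatter, and compound 1 stands higher still. Compound 4 `CCCC(=O)c1ccc(OCCCCOc2cc(C(=O)O)ccc2OC)c(C)c1O` differs from compound 3 in one place: methyl in place of hydrogen on a saturated chain carbon, two bonds along the chain from a carbonyl carbon. For the measured compounds named here, no pair of measured compounds shares exactly this change, so its size is not known from the data. Compound 1 reaches 98.8% and compound 2 reaches 85.7%, both carrying longer ketone chains than compound 3. On that basis a small rise in this assay is expected, about the size of the usual scatter, namely a number 11.4 percentage points higher from compound 3 to compound 4 (beyond the scatter). Compound 4 is therefore estimated at 84%, within 70% to 97%.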

Compound 4, largest response reached (reported as percent of maximum), in percent of the reference or control that the assay uses: 82.8%
Estimate against measurement, compound 4: 1.2 percentage points above; the range from low to high includes it.
By their numbers in this assay, from the lowest: compound 3; then compounds 4 and 2 (each within the scatter of the next); then compound 1.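

Within this assay this is the first direct reading at this position: methyl in place of hydrogen, which turns propanoyl into propylcarbonyl, gives a number 10.2 percentage points higher from compound 3 to compound 4 (beyond the scatter) as a modest rise. The earlier compounds shown here differed in several places at once, so they could not separate the effect of the ketone chain from the rest of the structure. No measurement shown here explains the rise. From the compounds shown here alone, whether a longer unbranched chain would raise the maximal response further, or an amine on that same carbon would preserve the rise, remains open.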